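Aryl piperazine series on MCF7: chloro moved within the ring

The source may report more compounds than this note shows. Statements on the series, on what has been measured and on what is new or still open speak of the compounds shown alone.

Compound 3 `COc1ccc(-c2nnc(N3CCN(C(=O)CN4CCN(c5ccccc5Cl)CC4)CC3)nc2-c2ccc(OC)cc2)cc1` stands only at a limit. In a functional assay on MCF7 cells (Homo sapiens) for cytotoxicity, read by MTT assay, with a stated time of 24 h (a lower number here means a stronger inhibitor, a higher number a weaker inhibitor), compound 3 gives > 814000 nM, which is a limit of the assay and not a number. Compound 2 `COc1ccc(-c2nnc(N3CCN(C(=O)CN4CCN(c5ccccc5)CC4)CC3)nc2-c2ccc(OC)cc2)cc1` likewise reaches only a limit. In this assay compound 2 gives > 863000 nM, again a limit. Compound 1 `Cc1ccc(-c2nnc(N3CCN(C(=O)CN4CCN(c5ccccc5)CC4)CC3)nc2-c2ccc(C)cc2)cc1` is the one of the three with a number, giving 914000 nM in this assay. The step that the two limits leave unreadable from compound 2 to compound 3 cannot be sized, since both of its ends sit at limits (the limit of > 814000 nM in this assay, at which 1 of the 3 values shown sits, (the limit of > 863000 nM in this assay, at which 1 of the 3 values shown sits)).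

Compound 4 `COc1ccc(-c2nnc(N3CCN(C(=O)CN4CCN(c5cccc(Cl)c5)CC4)CC3)nc2-c2ccc(OC)cc2)cc1` differs from compound 3 by 3-chlorophenyl in place of 2-chlorophenyl on an amine nitrogen in a ring. Among the measured compounds shown here, no measured step bears on moving the chlorine within the phenyl ring; the one step recorded gives no readable size. Nothing among the three measured compounds points to a step beyond the scatter in this assay. The expected step that the limit leaves unreadable from compound 3 to compound 4 is therefore within the scatter. The estimate for compound 4 is 900000 nM, between 500000 nM and 2000000 nM, most likely reported again as a limit.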

Compound 4, half-maximal inhibitory concentration: > 814000 nM
Compound 4: a limit, no number; the forecaster's own chance of this, stated with the estimate: 75%; the middle value lies beyond the limit too.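

In this assay compound 4 gives > 814000 nM, a limit of the assay and not a number. The steps from compound 2 and compound 3 to compound 4 cannot be read, with limits at both ends: the limit of > 814000 nM in this assay, at which 2 of the 4 values shown sit.

Going by these compounds, whether 3-chlorophenyl and 2-chlorophenyl differ at all in this assay stays open.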